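This account rests on a few compounds, and the source may have more. Where it says the series, first, only, none or still open, it means among the compounds named here.

In an ADME assay on the whole organism for pharmacokinetics, with Canis familiaris (Canis lupus familiaris) as the target, using cassette dosing (a lower number here means slower removal, a higher number faster removal of the compound), compound 2 `COc1ccc(CNC(=O)c2cc(-c3cncc(C)c3)ncc2-c2cnccn2)nc1OC` gives 24 mL/min/kg. Among the three compounds measured it stands second highest: compound 1 `COc1ccc(CNC(=O)c2cc(-c3cncc(C)c3)ncc2-c2cncc(F)c2)nc1OC` gives 19 mL/min/kg, which lies within the scatter of compound 2, while compound 3 `COc1ccc(CNC(=O)c2cc(-c3cncc(C)c3)ccc2-c2ccccc2)nc1OC` gives 51 mL/min/kg, a higher number beyond the scatter. Compound 4 `COc1ccc(CNC(=O)c2cc(-c3cncc(C)c3)ncc2N2CCC2)nc1OC` differs from compound 2 by azetidin-1-yl in place of pyrazin-2-yl on an aromatic carbon. For the measured compounds named here, the only measured step at this position is a 1.3-fold higher number from compound 1 to compound 2 (0.10 log units; within the scatter), an exchange of one aromatic ring for another, and it stayed within the scatter. Going by the values given here, no measured step replaces an aromatic ring with a four-membered non-aromatic ring, so the expectation rests loosely on that one small step and is a change within the scatter, a 1.1-fold lower number from compound 2 to compound 4 (0.04 log units; within the scatter). Compound 4 is therefore expected to give 22 mL/min/kg in this assay, with a range from 10 mL/min/kg to 45 mL/min/kg.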

Compound 4, clearance: 19 mL/min/kg
Compound 4: middle estimate off by 1.2-fold (0.06 log units), on the high side; the range from low to high includes it.
By their numbers in this assay, from the lowest: compounds 1, 4 and 2 (each within the scatter of the next); then compound 3.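

Until now this position had shown only one aromatic ring exchanged for another in this assay; the non-aromatic azetidin-1-yl now gives a 1.3-fold lower number from compound 2 to compound 4 (0.10 log units; within the scatter), and no change at the digits printed from compound 1 to compound 4 (within the scatter). Among these compounds, then, a four-membered non-aromatic ring with fewer heavy atoms takes the place of either aromatic ring without a step beyond the scatter. Nothing available explains this result. Still open, going by these compounds, is whether a larger saturated ring such as morpholine, or an open-chain dimethylamino group, on this aromatic carbon would also stay within the scatter of compound 4.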